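The source may hold more compounds than are shown below. What is called first, only, known or untested is meant among the compounds shown, and "the series" means these compounds.

Measured in a functional assay on HOS cells (Homo sapiens) for antiproliferative activity, with a stated time of 72 h (a lower number here means a stronger inhibitor, a higher number a weaker inhibitor), each entry being a limit and not a number:
- Compound 1 `OC[C@H]1O[C@@H](n2cnc3c(NCc4cccc(F)c4)ncnc32)[C@H](O)[C@@H]1O`: > 166000 nM
- Compound 2 `Cc1cccc(CNc2ncnc3c2ncn3[C@@H]2O[C@H](CO)[C@@H](O)[C@H]2O)c1`: > 166000 nM

Compound 2 has no numerical potency on this evidence. In this assay compound 2 gives > 166000 nM, which is a limit of the assay. Compound 1 is likewise known only by a limit, and the pair shares it: the limit of > 166000 nM in this assay, at which 2 of the 2 values shown sit.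

The next compound is compound 3 `COc1cccc(CNc2ncnc3c2ncn3[C@@H]2O[C@H](CO)[C@@H](O)[C@H]2O)c1OC`. It carries 2,3-dimethoxyphenyl in place of 3-methylphenyl on a saturated chain carbon bound to a nitrogen on an aromatic ring.

Among the measured compounds shown here, only one measured step bears on this change: a step that the two limits leave unreadable from compound 1 to compound 2, with methyl in place of fluoro on an aromatic carbon. It has no readable size, so it offers no measure of how far a change to this aromatic ring can move the result. With nothing to suggest a direction, no step beyond the scatter is expected in this assay, and another limit is the likeliest report. The expected step is a step that the limit leaves unreadable from compound 2 to compound 3. Compound 3 is estimated at 170000 nM, with an expected range from 60000 nM to 300000 nM.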

Compound 3, half-maximal inhibitory concentration: > 166000 nM
Compound 3: a limit, no number (the forecaster's own chance of this, stated with the estimate: 80%); the middle value does not contradict the limit.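

No step from compound 2 to compound 3, or from compound 1 to compound 3, can be read in this assay, since each compound is reported only as a limit: the limit of > 166000 nM in this assay, at which 3 of the 3 values shown sit.

The compounds shown leave open whether any change to the aromatic ring on the shared core can give a measurable potency in this assay.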